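Nitro for bromo on two cores of a cytotoxicity series

The source may hold more compounds than are shown below. What is called first, only, known or untested is meant among the compounds shown, and "the series" means these compounds.

Measured compounds:
compound 1 `C#CCOc1ccc(Br)cc1/C=N/Cc1ccc(S(N)(=O)=O)cc1`, 45700 nM
compound 2 `C#CCOc1ccc([N+](=O)[O-])cc1/C=N/Cc1ccc(S(N)(=O)=O)cc1`, 34800 nM
compound 3 `O=Cc1cc(Br)ccc1OCc1cn(CCCOc2ccc3ccc(=O)oc3c2)nn1`, 7470 nM

All three were read in a functional assay on HT-29 cells (Homo sapiens) for cytotoxicity, read by MTT assay, with a stated time of 24 h; a higher number here means a weaker inhibitor, a lower number a stronger inhibitor. Among the compounds with values here, the only step within one core is a 1.3-fold lower number from compound 1 to compound 2 (0.12 log units; within the scatter), the change being (nitro in place of bromo on an aromatic carbon). The difference between the core of compound 1 and the core of compound 3 is not broken down here; compound 3 gives the lowest of the three numbers in this assay.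

Compound 4 `O=Cc1cc([N+](=O)[O-])ccc1OCc1cn(CCCOc2ccc3ccc(=O)oc3c2)nn1` is not yet measured. It differs from compound 3 by nitro in place of bromo on an aromatic carbon, the same kind of change as from compound 1 to compound 2, though the place differs: here meta to a formyl group and para to a large group, there meta to a large group and para to a propargyloxy group.

A step of about the same small size is expected, a 1.2-fold lower number from compound 3 to compound 4 (0.10 log units; within the scatter), resting on the step measured from compound 1 to compound 2 in this assay, a 1.3-fold lower number from compound 1 to compound 2 (0.12 log units; within the scatter). Compound 4 is therefore estimated at 6000 nM in this assay, with a range from 2500 nM to 15000 nM.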

Compound 4, half-maximal inhibitory concentration: 53600 nM
For compound 4 the middle estimate is 8.9-fold (0.95 log units) below the measured one; the measured number lies above the stated range.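

In this assay, the effect of nitro in place of bromo does not carry from one core to the other: the same change on two cores in this assay, a 1.3-fold lower number (0.12 log units; within the scatter) from compound 1 to compound 2 and a 7.2-fold higher number (0.86 log units; beyond the scatter) from compound 3 to compound 4, 9.4-fold (0.97 log units) apart, beyond the scatter of two such steps

On the formyl-bearing core the step is a 7.2-fold higher number from compound 3 to compound 4 (0.86 log units; beyond the scatter), so its size there cannot be taken from the core with the propargyloxy group. Within the data shown here, with only one pair on each core, the data do not show which part of the cores accounts for the gap, or how the change would behave on a further core.

On these data alone, whether the higher number is specific to nitro remains open, as a chloro or nitrile in the same place would be needed to test it. Also open, as far as these compounds go, is whether an amine or carboxylic acid in place of the formyl group would alter the step.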